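The source may hold more compounds than are shown below. What is called first, only, known or untested is meant among the compounds shown, and "the series" means these compounds.

Measured in a functional assay on HepG2 cells (Homo sapiens) for inhibition, read by WST assay, with stated times of 72 h and 2 h; a lower number here means a stronger inhibitor, a higher number a weaker inhibitor:
- compound 1 `OC(c1cccs1)c1cc2ccccc2nc1Cl`: 80800 nM
- compound 2 `Oc1ccc(-c2cc(COC(c3cccs3)c3cc4ccccc4nc3Cl)on2)cc1`: 179000 nM
- compound 3 `FC(F)(F)c1cccc(COC(c2cccs2)c2cc3ccccc3nc2Cl)c1`: "not active" (no number reported)

Compound 1 holds the lower of the two numbers, and the gap up to compound 2 lies beyond the usual scatter. Compound 3 gave no number.

Compound 4 `Clc1ccc(COC(c2cccs2)c2cc3ccccc3nc2Cl)cc1` has 4-chlorobenzyl in place of hydrogen on an oxygen on a saturated carbon. Compound 2 and compound 3 also carry a larger group on that oxygen, and neither gives a number below that of compound 1. A modest rise in this assay is therefore expected, and the expected size is a 1.6-fold higher number from compound 1 to compound 4 (0.21 log units; within the scatter). The estimated value for compound 4 is 130000 nM, with an expected range from 55000 nM to 300000 nM.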

Compound 4, half-maximal inhibitory concentration: "not active" (no number reported)
The entry for compound 4 holds no number; no gap can be computed for the estimate.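

Within the data shown here, compound 4, like compound 3, gave no number, so no step from compound 1 to compound 4 can be read, and no supporting evidence bears on this result. Still open, going by these compounds, is whether any group on that oxygen improves on compound 1 at 80800 nM in this series.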